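A Fluoro Substitution on the Shared Core

A few compounds are considered here, and "the series" means these few. Any claim that something is new, unique, unknown or untested is made for them only; others in the source may bear on it.

The measured compounds and their values in an assay on isolated protein for agonist activity at Bile acid receptor (Homo sapiens), read by TR-FRET (a higher number here means that more compound is needed for the effect, a lower number that less compound is needed), are:
compound 1 `CCC(CC)n1c(-c2ccc(OCc3c(-c4c(Cl)cccc4Cl)noc3C(C)C)cc2)nc2ccc(C(=O)O)cc21`: 26.5 nM
compound 2 `CCn1c(-c2ccc(OCc3c(-c4c(Cl)cccc4Cl)noc3C(C)C)cc2)nc2ccc(C(=O)O)cc21`: 19.3 nM
compound 3 `CC(C)c1onc(-c2c(Cl)cccc2Cl)c1COc1ccc(-c2nc3ccc(C(=O)O)cc3n2C(C)C)cc1`: 56.7 nM

Compound 1 holds the second highest of the three numbers in this assay. Its nearest neighbour is compound 2, reached by a 1.4-fold lower number from compound 1 to compound 2 (0.14 log units; within the scatter), a change that stays within the scatter. The furthest is compound 3, reached by a 2.1-fold higher number from compound 1 to compound 3 (0.33 log units; beyond the scatter), and the same compound 3 is reached from compound 2 by a 2.9-fold higher number from compound 2 to compound 3 (0.47 log units; beyond the scatter). All three measured steps change only the group on the aromatic nitrogen of the shared core.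

Compound 4 `CCC(CC)n1c(-c2ccc(OCc3c(-c4c(Cl)cccc4Cl)noc3C(C)C)cc2F)nc2ccc(C(=O)O)cc21` differs from compound 1 in a different place: fluoro in place of hydrogen on an aromatic carbon. Within the data shown here, none of the measured steps touches this part of the structure, so there is no step among the measured compounds that bears on the change directly. With nothing pointing in either direction, the expectation is a step of no more than the scatter, written as a 1.0-fold lower number from compound 1 to compound 4 (0.01 log units; within the scatter). Compound 4 is therefore estimated to give about 26 nM in this assay, with a range from 9 nM to 75 nM.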

Compound 4, half-maximal effective concentration: 69.3 nM
The estimate for compound 4 lay 2.7-fold (0.43 log units) below the measured number; the measured number falls inside the stated range.
By their numbers in this assay, from the lowest: compounds 2 and 1 (each within the scatter of the next); then compounds 3 and 4 (each within the scatter of the next).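

In this assay, fluoro in place of hydrogen on an aromatic carbon, ortho to a large group and meta to a large group, gives a 2.6-fold higher number from compound 1 to compound 4 (0.42 log units; beyond the scatter), a modest step but one beyond the scatter. Among these compounds, the earlier compounds differed only in the group on the aromatic nitrogen, so this is the first sign that the number also responds to a change elsewhere on the shared core, and here that single fluoro moves it upward, so that more compound is needed for the effect. Nothing among the data shown accounts for this rise, which therefore stands as an observation about compound 1 and compound 4 alone.

From the compounds shown here alone, it remains open whether the same fluoro would raise the number to a similar extent on the ethyl compound 2 or the isopropyl compound 3, where the group on the aromatic nitrogen differs. Also open, going by these compounds, is how a chloro, methyl or methoxy group would behave on this same aromatic carbon, and whether fluoro on another carbon of this ring would give a step of the same direction.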